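The source may report more compounds than this note shows. Statements on the series, on what has been measured and on what is new or still open speak of the compounds shown alone.

Measured compounds and their values in a functional assay on U226 cells (Homo sapiens) for cytotoxicity; a lower number here means that less compound is needed, a higher number that more compound is needed for the effect:

- compound 1 `CC(=O)SCC(=O)c1ccc(NS(=O)(=O)c2ccc(OC3CCCN(C)C3)cc2)nc1`: 1200 nM
- compound 2 `CC(=O)SCC(=O)c1ccc(NS(=O)(=O)c2ccc(OCCCO)cc2)nc1`: "not determined" (no result reported)
- compound 3 `CC(=O)SCC(=O)c1ccc(NS(=O)(=O)c2ccc(OCc3ccccn3)cc2)nc1`: "not determined" (no result reported)

Where compound 2 stands cannot be read from a number: in this assay compound 2 has no reported result, and compound 3 likewise has none, so the only number in this set belongs to compound 1. For the measured compounds named here, no pair of measured compounds differing in one place is available, and so no measured step exists from which a direction could be taken.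

Compound 4 `COCCCOc1ccc(S(=O)(=O)Nc2ccc(C(=O)CSC(C)=O)cn2)cc1` follows from compound 2 by one change, (methyl in place of hydrogen on an oxygen on a saturated carbon). Going by the values given here, with no step of this kind measured anywhere in the set, the expectation for this change is that it stays within the scatter of this assay, in no particular direction. Among the compounds with values here, the only anchor is compound 1, whose value is the sole number known, and the estimate for compound 4 rests on it loosely. Compound 4 is therefore expected to give about 1500 nM in this assay, with a range from 400 nM to 6000 nM, and a real chance that no number is reported at all.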

Compound 4, half-maximal effective concentration: 29000 nM
The estimate for compound 4 lay 19-fold (1.29 log units) below the measured number; measured number above the stated range.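

In this assay, placing 3-methoxypropyl instead of 1-methylpiperidin-3-yl on the oxygen on the aromatic ring gives a 24-fold higher number from compound 1 to compound 4 (1.38 log units; beyond the scatter), a large step beyond the scatter. For the compounds shown here, this shows that the group on this oxygen matters in this assay, which the earlier compounds could not show while compound 1 alone had a number. From the compounds shown here alone, the hydroxy to methoxy change itself cannot be read, since compound 2 has no reported result, so the effect of the methyl alone remains unknown.

The compounds shown leave open whether the lower number of compound 1 goes with its amine or with its piperidine ring, a question that an open-chain 3-(dimethylamino)propyl group would address. Nothing shown gives a reason for the size of this step.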